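Removing the Urea Carbonyl at the Proline Nitrogen

The source may report more compounds than this note shows. Statements on the series, on what has been measured and on what is new or still open speak of the compounds shown alone.

Compound 1: `CC(C)C(=O)N1CCC[C@H]1C(=O)N1CCC(NS(=O)(=O)c2cc(S(=O)(=O)c3ccccc3)ccc2C(F)(F)F)CC1`, 40 nM
Compound 2: `O=C([C@@H]1CCCN1C(=O)Nc1ccccc1)N1CCC(NS(=O)(=O)c2cc(S(=O)(=O)c3ccccc3)ccc2C(F)(F)F)CC1`, 20 nM

In an assay on isolated protein for binding affinity to secreted frizzled-related protein 1 (Homo sapiens), read by fluorescence (a higher number here means a weaker inhibitor, a lower number a stronger inhibitor), compound 2 gives 20 nM, the lowest of the two numbers; its nearest neighbour is compound 1 with 40 nM. Compound 3, `O=C([C@@H]1CCCN1Cc1ccccc1)N1CCC(NS(=O)(=O)c2cc(S(=O)(=O)c3ccccc3)ccc2C(F)(F)F)CC1`, differs from compound 2 by benzyl in place of phenylcarbamoyl on an amine nitrogen in a ring. Among the compounds with values here, the only measured step, a 2.0-fold lower number from compound 1 to compound 2 (0.30 log units; within the scatter), swapped one carbonyl-bound group for another and kept the carbonyl, so it bears only loosely on this change. Within the data shown here, with no step that removes the carbonyl, a modest weakening within a wide range is expected, a 3.0-fold higher number from compound 2 to compound 3 (0.48 log units; beyond the scatter). Compound 3 is estimated at 60 nM, between 15 nM and 300 nM.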

Compound 3, half-maximal inhibitory concentration: 1400 nM
Compound 3: middle estimate off by 23-fold (1.37 log units), on the low side; measured number above the stated range.
By their numbers in this assay, from the lowest: compounds 2 and 1 (each within the scatter of the next); then compound 3.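

Putting benzyl on this ring nitrogen gives a 70-fold higher number from compound 2 to compound 3 (1.85 log units; beyond the scatter) and a 35-fold higher number from compound 1 to compound 3 (1.54 log units; beyond the scatter). Compound 1 and compound 2 both keep a carbonyl on this nitrogen and sit within the scatter of each other, despite carrying different groups on that carbonyl, whereas compound 3 has no carbonyl there and stands well apart. No measurement here explains this loss.

On these data alone, whether the carbonyl itself is what counts remains open. A sulfonyl group on this nitrogen, or a simple methyl, could help separate the carbonyl from the other differences.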